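Adding a trifluoromethyl group to compound 1

This account rests on a few compounds, and the source may have more. Where it says the series, first, only, none or still open, it means among the compounds named here.

In a functional assay on A2780 cells (Homo sapiens) for inhibition, read by MTT assay, with a stated time of 72 h (a higher number here means a weaker inhibitor, a lower number a stronger inhibitor), compound 1 `O=C1/C(=C\c2ccccc2)c2c(ncn2COCc2ccccc2)CCN1Cc1ccccc1` gives 20400 nM. Among the measured compounds shown here, the only other measured compound, compound 2 `Cc1ccccc1CN1CCc2ncn(COCc3ccccc3)c2/C(=C/c2ccccc2)C1=O`, gives 25300 nM, so the two values lie within the scatter of each other. Compound 3 `O=C1/C(=C\c2ccc(C(F)(F)F)cc2)c2c(ncn2COCc2ccccc2)CCN1Cc1ccccc1` has not yet been measured. It differs from compound 1 by trifluoromethyl in place of hydrogen on an aromatic carbon, which turns phenyl into 4-(trifluoromethyl)phenyl: trifluoromethyl in place of hydrogen on an aromatic carbon. For the measured compounds named here, the only measured step is a 1.2-fold higher number from compound 1 to compound 2 (0.09 log units; within the scatter), for methyl in place of hydrogen on an aromatic carbon elsewhere in the molecule. Going by the values given here, no measured compound carries a trifluoromethyl group, so this step is a weak guide, and no change beyond the scatter is expected in this assay. The expected step is a 1.3-fold lower number from compound 1 to compound 3 (0.11 log units; within the scatter). Compound 3 is estimated at 16000 nM, with an expected range of 6000 nM to 40000 nM.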

Compound 3, half-maximal inhibitory concentration: 28200 nM
Beside the measured number, compound 3's estimate is 1.8-fold (0.25 log units) below it; measured number inside the range.
By their numbers in this assay, from the lowest: compounds 1, 2 and 3 (each within the scatter of the next).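

Turning phenyl into 4-(trifluoromethyl)phenyl in this assay gives a 1.4-fold higher number from compound 1 to compound 3 (0.14 log units; within the scatter), so this group of four heavy atoms, placed on an aromatic carbon of this ring, leaves the number inside the usual scatter. The earlier pair showed this only for a methyl group elsewhere in the molecule, so the finding extends to a second place and to a larger group. Nothing shown here gives a measured reason why the step stays so small.

All three compounds lie within the scatter of one another. They do not yet show which changes to the shared core matter in this assay. Going by these compounds, it remains open whether a different group at this place, such as an amine, a carboxylic acid or a longer alkyl chain, would shift the number beyond the scatter.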